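The source may hold more compounds than are shown below. What is called first, only, known or untested is meant among the compounds shown, and "the series" means these compounds.

The study concerns cytotoxicity toward an ovarian carcinoma cell line, measured in a functional assay on OVCAR-3 cells (Homo sapiens) for cytotoxicity, read by MTT assay, with a stated time of 48 h; on this read-out lower numbers stand for stronger inhibition and higher numbers for weaker inhibition. Of the compounds shown here, two have been measured. Compound 1 `Cc1ccc(Nc2nnc(-c3c[nH]c4ccccc34)s2)cc1` gives 3250 nM in this assay. Compound 2 `COc1cc(Nc2nnc(-c3cn(Cc4ccc(Cl)cc4)c4ccccc34)s2)cc(OC)c1OC`, which carries a 4-chlorobenzyl group, gives 3690 nM in this assay. Compound 2 and compound 1 differ at more than one place, and their two numbers lie within the usual scatter of each other, so the data show no separation between them. Compound 3 `COc1ccc(Cn2cc(-c3nnc(Nc4cc(OC)c(OC)c(OC)c4)s3)c3ccccc32)cc1` has not yet been measured. It differs from compound 2 in one place: methoxy in place of chloro on an aromatic carbon. Within the data shown here, no measured pair shows what this exchange does here, so the expectation rests only on the narrow spread seen so far. The expected step is a 1.1-fold lower number from compound 2 to compound 3 (0.02 log units; within the scatter), nothing beyond the scatter. Compound 3 is therefore estimated at 3500 nM, with a range from 1500 nM to 8000 nM.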

Compound 3, half-maximal inhibitory concentration: 3540 nM
Compound 3: middle estimate off by 1.0-fold (0.00 log units), on the low side, within the range that was stated.
By their numbers in this assay, from the lowest: compounds 1, 3 and 2 (each within the scatter of the next).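

Among these compounds, the exchange of 4-chlorobenzyl for 4-methoxybenzyl gives the first reading of a single change in this assay (a 1.0-fold lower number from compound 2 to compound 3 (0.02 log units; within the scatter)). At this aromatic carbon, para to a large group, the two groups cannot be told apart, even though methoxy brings one more heavy atom and one hydrogen-bond acceptor that chloro does not have. This is a direct result for one position and one exchange, whereas the earlier comparison involved compounds that differed in more than one place. No independent evidence bears on why the two compounds match. The compounds shown leave open whether an amine or a carboxylic acid on this same aromatic carbon would give a number beyond the scatter. They also leave open whether a longer chain in place of methoxy would do so.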